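Working notes: from 4-chlorophenyl to 3-chlorophenyl

The compounds below may be only part of what the source reports. "The series", "measured", "known", "first", "only" and "open" are said of these compounds alone.

Of the compounds shown here, two have numbers so far, compound 1 (`C=CC(=O)N1C(=O)CC(c2ccc(Cl)cc2)Sc2ccccc21`) and compound 2 (`C=CC(=O)N1C(=O)CC(c2ccccc2C(F)(F)F)Sc2ccccc21`). In a functional assay on MOLT-4 cells (Homo sapiens) for cytotoxicity, read by CCK-8 assay, with a stated time of 24 h (a higher number here means a weaker inhibitor, a lower number a stronger inhibitor), compound 1 gives 82400 nM and compound 2 gives 84400 nM as its reading. These two numbers lie within the scatter of each other, so compound 1 stands level with compound 2 and the pair cannot be ranked.

Compound 3 (`C=CC(=O)N1C(=O)CC(c2cccc(Cl)c2)Sc2ccccc21`) keeps the core of compound 1 and carries 3-chlorophenyl in place of 4-chlorophenyl on a saturated ring carbon, next to the ring sulfur (3-chlorophenyl in place of 4-chlorophenyl on a saturated ring carbon). Within the data shown here, no measured step for this change exists, and two compounds establish no trend. In this assay, among the measured compounds shown here, no step beyond the scatter is therefore expected, the only guide being that compound 1 at 82400 nM and compound 2 at 84400 nM sit together within the scatter.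

The estimated value for compound 3 is 80000 nM with an expected range from 45000 nM to 130000 nM in this read-out. This estimate corresponds to a 1.0-fold lower number from compound 1 to compound 3 (0.01 log units; within the scatter) as an expected change, one that stays within the scatter.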

Compound 3, half-maximal inhibitory concentration: 77500 nM
For compound 3 the middle estimate is 1.0-fold (0.01 log units) above the measured one, within the range that was stated.
By their numbers in this assay, from the lowest: compounds 3, 1 and 2 (each within the scatter of the next).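

Among these compounds, the step of a 1.1-fold lower number from compound 1 to compound 3 (0.03 log units; within the scatter) is the first measured step at this position, and it concerns only where the chlorine sits on the phenyl group, with 3-chlorophenyl in place of 4-chlorophenyl on a saturated ring carbon next to the ring sulfur. In this assay this exchange of two groups with the same atoms gives no readable change, so compound 1 and compound 3 stand level and cannot be ranked. At this stage the series therefore offers no sign that this assay separates these two chlorophenyl isomers, although a single pair sets no rule for other groups at this position. No supporting measurement bears on this result, so nothing can be said about what lies behind it.

On these data alone, it remains open whether an amine or a carboxylic acid on the phenyl group, in place of the chlorine, would give a step beyond the scatter at this position. As far as these compounds go, it is equally open how the series would read in this assay with a saturated propanoyl group in place of the vinylcarbonyl group on the shared core.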